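Removing a Methyl from the Core of Compound 3

The source may report more compounds than this note shows. Statements on the series, on what has been measured and on what is new or still open speak of the compounds shown alone.

Compound 3 `COc1cc2oc(-c3cccc(C(=O)Nc4ccc(Cl)cc4)c3)cc(=O)c2c(OC)c1OC` gives 88% in a functional assay on 786-0 cells (Homo sapiens) for inhibition, read by sulforhodamine B assay, tested at 10 uM (a higher number here means more inhibition at the concentration tested (going by the name of the read-out), a lower number less inhibition), the highest of the three measured numbers. Compound 1 `COc1cc2oc(-c3cccc(NC(=O)c4ccc(Br)cc4)c3)cc(=O)c2c(OC)c1OC` gives 84%, and the difference a number 4 percentage points higher from compound 1 to compound 3 (within the scatter) lies within the scatter. Compound 2 `COc1cc2oc(-c3cccc(C(=O)Nc4ccc(C)cc4)c3)cc(=O)c2c(OC)c1OC` gives 55.7%, and the step of a number 32.3 percentage points higher from compound 2 to compound 3 (beyond the scatter) is large. Compound 4 `COc1cc2oc(-c3cccc(C(=O)Nc4ccc(Cl)cc4)c3)cc(=O)c2c(O)c1OC` differs from compound 3 by hydrogen in place of methyl on an oxygen on an aromatic ring. Within the data shown here, every measured step, including a number 28.3 percentage points lower from compound 1 to compound 2 (beyond the scatter), changes the group on the other ring and leaves the shared core untouched, so no measured step bears on this oxygen and none points to a direction. The expected step, a number 8 percentage points lower from compound 3 to compound 4 (within the scatter), lies within the scatter. Compound 4 is therefore estimated at 80%, in a range from 55% to 97%.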

Compound 4, a percentage reported as inhibition, at one concentration (the size of the read-out at that concentration, not a potency): 53%
For compound 4 the middle estimate is 27 percentage points above the measured one, and the stated range ends above it.
By their numbers in this assay, from the lowest: compounds 4 and 2 (each within the scatter of the next); then compounds 1 and 3 (each within the scatter of the next).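

Among these compounds, every earlier step changed the group on the other ring, so this is the first reading from the shared core. In this assay, going from methoxy to hydroxy on this oxygen gives a number 35 percentage points lower from compound 3 to compound 4 (beyond the scatter), showing that removing one methyl carbon here can move the number beyond the scatter. Nothing shown here gives a reason for this drop.

As far as these compounds go, whether an ethoxy group or a longer chain on this oxygen would hold the higher number stays open. So does what the other methoxy groups on the core contribute.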